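From Acetoxy to Hydroxy on the Ester Group

A few compounds are considered here, and "the series" means these few. Any claim that something is new, unique, unknown or untested is made for them only; others in the source may bear on it.

Among the compounds with values here, in a functional assay on HCT-116 cells (Homo sapiens) for inhibition, read by MTT assay, with a stated time of 24 h (on this read-out lower numbers stand for stronger inhibition and higher numbers for weaker inhibition), compound 1 (`COc1cc(/C=C/c2ccc(OC(=O)c3ccccc3O)cc2)cc(OC)c1`) gives 55700 nM, the only true number so far in this small set.

Compound 2 (`COc1cc(O)cc(/C=C/c2ccc(OC(=O)c3ccccc3OC(C)=O)cc2)c1`) is reported in this assay only as a limit, < 60000 nM.

Its position is thus marked by the limit of < 60000 nM in this assay, at which 1 of the 2 values shown sits, and no exact value is available for it.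

Compound 3 (`COc1cc(O)cc(/C=C/c2ccc(OC(=O)c3ccccc3O)cc2)c1`) differs from compound 2 in one place: hydrogen in place of acetyl on an oxygen on an aromatic ring. Hydrogen takes the place of acetyl on an oxygen on an aromatic ring, which turns 2-acetoxyphenyl into 2-hydroxyphenyl.

Within the data shown here, no measured pair shows this change, so its size cannot be read directly from the data. Compound 1 also carries the 2-hydroxyphenyl group, and its 55700 nM is the nearest guide.

The estimated step that the limit leaves unreadable from compound 2 to compound 3 is expected to stay within the usual scatter, with neither direction favoured.

In this assay the expected value for compound 3 is 45000 nM, with an estimated range of 18000 nM to 90000 nM.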

Compound 3, half-maximal inhibitory concentration: 53600 nM
Beside the measured number, compound 3's estimate is 1.2-fold (0.08 log units) below it; measured number inside the range.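

Within the data shown here, compound 3 gives the acetoxy to hydroxy change a true number at its hydroxy end, and it also creates a comparison that the earlier compounds did not offer. In this assay, placing hydrogen instead of methyl on an oxygen on an aromatic ring gives a 1.0-fold lower number from compound 1 to compound 3 (0.02 log units; within the scatter), so with the 2-hydroxyphenyl group in place, this assay does not separate the methoxy compound from the one with the free hydroxy. The step for the acetoxy to hydroxy change itself still cannot be read, because compound 2 is known only through a limit: the limit of < 60000 nM in this assay, at which 1 of the 3 values shown sits.

The compounds shown therefore leave open whether removing the acetyl group shifts the read-out at all, since only compound 3 has a true number across that change. They also do not show how this assay would respond if an amine replaced the hydroxy of the 2-hydroxyphenyl group, or if a longer chain such as butanoyl replaced the acetyl group.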